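From 2-methylphenyl to 4-ethylphenyl: one change, one estimate

The compounds below may be only part of what the source reports. "The series", "measured", "known", "first", "only" and "open" are said of these compounds alone.

Compound 1 `Cc1ccccc1-c1nc(CNc2ccc(C(=O)NO)cc2)n(-c2ccccc2)n1` was tested in an assay on Sf9 cells for inhibition of protein deacetylase HDAC6 (Homo sapiens), read by fluorescence, with a stated time of 40 min, tested at 100 nM (on this read-out lower numbers stand for less inhibition and higher numbers for more inhibition at the one concentration tested (going by the name of the read-out)), where compound 1 gives 53.2%. Compound 2 `Cc1ccc(-n2nc(-c3ccccc3)nc2CNc2ccc(C(=O)NO)cc2)cc1C` was run in the same setting; in this assay compound 2 gives 53%. Compound 1 stands at the top of these two numbers only nominally, as the gap to compound 2 is within the usual scatter, so the two cannot be ranked against each other. Compound 3 `CCc1ccc(-c2nc(CNc3ccc(C(=O)NO)cc3)n(-c3ccccc3)n2)cc1` has not yet been measured. It differs from compound 1 in one place: 4-ethylphenyl in place of 2-methylphenyl on an aromatic carbon. Among the measured compounds shown here, no pair of measured compounds shows what such a change does in this assay, so there is no earlier step to lean on. Starting from compound 1 at 53.2% and with nothing pointing either way, the step of a number 3.2 percentage points lower from compound 1 to compound 3 (within the scatter) is expected to stay within the scatter. Compound 3 is estimated to give 50%, with a range from 30% to 70%.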

Compound 3, a percentage reported as inhibition, at one concentration (the size of the read-out at that concentration, not a potency): 54.6%
Estimate against measurement, compound 3: 4.6 percentage points below; the range from low to high includes it.
By their numbers in this assay, from the lowest: compounds 2, 1 and 3 (each within the scatter of the next).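

Among the compounds shown here, this is the first measured step at this position, on an aromatic carbon of the five-membered aromatic ring with 3 nitrogen: in this assay, 4-ethylphenyl in place of 2-methylphenyl gives a number 1.4 percentage points higher from compound 1 to compound 3 (within the scatter). At the one concentration tested, the two groups therefore cannot be told apart, although the entering group has 8 heavy atoms against 7 and carries its substituent at a different place on the phenyl ring. Nothing available explains why they read alike.

On these data alone, both groups contain carbon only, so it remains open whether a phenyl ring bearing an amine, a carboxylic acid or a longer chain such as butyl would also stay within the scatter of compound 1. A reading at a single concentration also leaves open whether full potency measurements would separate compound 1 and compound 3.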